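From pyridin-3-yl to pyridin-4-yl in the series

A few compounds are considered here, and "the series" means these few. Any claim that something is new, unique, unknown or untested is made for them only; others in the source may bear on it.

Within the data shown here, in a functional assay on HepG2 cells (Homo sapiens) for cytotoxicity, read by MTT assay, with a stated time of 24 h (a lower number here means a stronger inhibitor, a higher number a weaker inhibitor), compound 1 (`COc1ccc(/C=C2\CN(C)C/C(=C\c3cccnc3)C2=O)c(OC)c1OC`) gives 5160 nM as the higher of two numbers so far, and compound 2 (`CN1C/C(=C\c2cccnc2)C(=O)/C(=C/c2ccccc2C(F)(F)F)C1`) gives 2550 nM as a lower number, beyond the usual scatter. Compound 3 (`COc1ccc(/C=C2\CN(C)C/C(=C\c3ccncc3)C2=O)c(OC)c1OC`) carries pyridin-4-yl in place of pyridin-3-yl on a double-bonded chain carbon bound to a double-bonded ring carbon. Among the measured compounds shown here, no measured pair isolates this change, so in this assay no step beyond the scatter is expected. The estimated step (a 1.2-fold lower number from compound 1 to compound 3 (0.09 log units; within the scatter)) has no firm direction. For compound 3 the expected value is 4200 nM with a range from 1800 nM to 9500 nM as an estimate.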

Compound 3, half-maximal inhibitory concentration: 3560 nM
The estimate for compound 3 lay 1.2-fold (0.07 log units) above the measured number, within the range that was stated.
By their numbers in this assay, from the lowest: compounds 2, 3 and 1 (each within the scatter of the next, the first and the last beyond it).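

On a double-bonded chain carbon bound to a double-bonded ring carbon, pyridin-4-yl in place of pyridin-3-yl gives a 1.4-fold lower number from compound 1 to compound 3 (0.16 log units; within the scatter) in this assay. Among these compounds, this is the first pair to isolate a change at this position, and the exchange leaves no readable preference between the two pyridine attachments. Nothing measured here bears on a cause for this result.

As far as these compounds go, whether a phenyl group or a pyrimidine ring at this place would also stay within the scatter remains open. Also open, from the compounds shown here alone, is whether pyridin-4-yl gives the same result with the trifluoromethyl-bearing side of compound 2.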